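Replacing the trifluorophenyl group of compound 3

This account rests on a few compounds, and the source may have more. Where it says the series, first, only, none or still open, it means among the compounds named here.

In a functional assay on K562 cells (Homo sapiens) for antiproliferative activity, with a stated time of 72 h (a lower number here means a stronger inhibitor, a higher number a weaker inhibitor), compound 1 `OC[C@H]1O[C@@H](n2cnc3c(NCc4ccc(F)cc4)ncnc32)[C@H](O)[C@@H]1O` gives 2700 nM, and compound 2 `OC[C@H]1O[C@@H](n2cnc3c(NCc4ccc(F)cc4F)ncnc32)[C@H](O)[C@@H]1O` gives 9600 nM. Compound 3 `OC[C@H]1O[C@@H](n2cnc3c(NCc4ccc(F)c(F)c4F)ncnc32)[C@H](O)[C@@H]1O` stands at > 166000 nM, which is a limit of the assay and not a number. It is the only limit among the three compounds (the limit of > 166000 nM in this assay, at which 1 of the 3 values shown sits).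

Compound 4 `OC[C@H]1O[C@@H](n2cnc3c(NCc4ccc(F)cc4Cl)ncnc32)[C@H](O)[C@@H]1O` has 2-chloro-4-fluorophenyl in place of 2,3,4-trifluorophenyl, on a saturated chain carbon bound to a nitrogen on an aromatic ring (2-chloro-4-fluorophenyl in place of 2,3,4-trifluorophenyl on a saturated chain carbon bound to a nitrogen on an aromatic ring).

Going by the values given here, three measured steps bear on this change. The first is modest: a 3.6-fold higher number from compound 1 to compound 2 (0.55 log units; beyond the scatter). The other two are large: an at least 17-fold higher number from compound 2 to compound 3 (1.23 log units; beyond the scatter), and an at least 61-fold higher number from compound 1 to compound 3 (1.78 log units; beyond the scatter). Across these three compounds, each added fluoro raises the number, and none goes against this. The loss of activity therefore appears tied to the 2,3,4-trifluorophenyl group that leaves in compound 4. On these data alone, no chloro has been measured, so that part of the change remains untested, and the expectation is correspondingly loose. Compound 4 is expected to lie near compound 2 at 9600 nM.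

A large move to a lower number is expected in this assay, with the estimated step being an at least 18-fold lower number from compound 3 to compound 4 (1.26 log units; beyond the scatter). The estimated value for compound 4 is 9000 nM, with an expected range of 2500 nM to 40000 nM.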

Compound 4, half-maximal inhibitory concentration: 15600 nM
Estimate against measurement, compound 4: 1.7-fold (0.24 log units) below; low and high end bracket the measured number.
By their numbers in this assay, from the lowest: compound 1; then compounds 2 and 4 (each within the scatter of the next). At a limit, above all of these: compound 3.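

In this assay, the step shows an at least 10-fold lower number from compound 3 to compound 4 (1.02 log units; beyond the scatter), so a measurable number returns once the 2,3,4-trifluorophenyl group gives way to 2-chloro-4-fluorophenyl, and the collapse seen at compound 3 does not carry over to this second halogenated ring. Compound 3 remains a limit of the assay and not a number, so the true size of that step cannot be read: the limit of > 166000 nM in this assay, at which 1 of the 4 values shown sits. Chloro in place of fluoro on an aromatic carbon gives a 1.6-fold higher number from compound 2 to compound 4 (0.21 log units; within the scatter), which lies within the scatter, while the same chloro set against hydrogen at that carbon gives a 5.8-fold higher number from compound 1 to compound 4 (0.76 log units; beyond the scatter), so compound 1 stays the strongest of the four and neither halogen improves on hydrogen at that carbon.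

The compounds shown do not separate the effect of the third fluoro from that of the 2,3,4-trifluorophenyl group as a whole, since no other group appears in that arrangement. On these data alone, it also stays open whether a methyl, a methoxy or a nitrile on the phenyl ring, in place of chloro or fluoro, would bring a number below that of compound 1 at 2700 nM.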